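This account rests on a few compounds, and the source may have more. Where it says the series, first, only, none or still open, it means among the compounds named here.

Measured so far:
compound 1, `O=[N+]([O-])c1cc(Cl)ccc1CNc1cc(C(F)(F)F)cc2[nH]ncc12`: 77%
compound 2, `N#Cc1cc(NCc2ccccc2[N+](=O)[O-])c2cn[nH]c2c1`: 17%
compound 3, `COC(=O)c1cc(NCc2ccccc2[N+](=O)[O-])c2cn[nH]c2c1`: 47%

These three compounds share a core and differ in the group attached to one aromatic carbon of that core; compound 1 additionally carries a chlorine elsewhere. In an assay for inhibition of Indoleamine 2,3-dioxygenase 1 (Homo sapiens), with stated times of 10 min and 60 min, tested at 100 uM (a higher number here means a stronger effect of the compound at the concentration tested, a lower number a weaker effect), compound 3 gives 47%, the second highest of the three numbers: compound 1 gives 77%, a higher number, and compound 2 gives 17%, a lower one. Among the measured compounds shown here, the only measured step that changes just this group is a number 30 percentage points higher from compound 2 to compound 3 (beyond the scatter).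

Compound 4, `O=[N+]([O-])c1ccccc1CNc1cc(C(F)(F)F)cc2[nH]ncc12`, has not yet been measured. It differs from compound 3 in one place: trifluoromethyl in place of methoxycarbonyl on an aromatic carbon. For the measured compounds named here, no measured step exchanges exactly these two groups. The step from compound 2 to compound 3 shows that the group at this position can shift the number by a modest amount. Compound 1, which also carries trifluoromethyl, gives a higher number than compound 3, although it differs in a second place as well, so this is only a hint. Compound 4 is therefore expected to give a modestly higher number than compound 3, a step of a number 15 percentage points higher from compound 3 to compound 4 (beyond the scatter). The estimate for compound 4 is 62%, within 42% to 80%.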

Compound 4, a percentage reported as inhibition, at one concentration (the size of the read-out at that concentration, not a potency): 76%
Compound 4: the middle estimate sits 14 percentage points below what was measured; measured number inside the range.
By their numbers in this assay, from the lowest: compound 2; then compound 3; then compounds 4 and 1 (each within the scatter of the next).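

With the rest of the molecule held constant, this position now compares three groups in this assay: trifluoromethyl in place of methoxycarbonyl gives a number 29 percentage points higher from compound 3 to compound 4 (beyond the scatter), and trifluoromethyl in place of cyano gives a number 59 percentage points higher from compound 2 to compound 4 (beyond the scatter), so the position can separate these groups widely and trifluoromethyl ranks above both. Among the compounds shown here, removing the chlorine gives a number 1 percentage points lower from compound 1 to compound 4 (within the scatter), which means the high number of compound 1 goes with the trifluoromethyl group and does not depend on the chlorine, something the earlier compounds could only hint at. Nothing available explains why these groups rank in this order.

The compounds shown leave open how a plain hydrogen, an amine or a carboxylic acid would fare at this position, and whether the chlorine would also make no visible difference alongside cyano or methoxycarbonyl. On these data alone, each number also comes from a single concentration, so it remains open whether compound 1 and compound 4 would match in potency, since that needs a full concentration series.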